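Swapping Hydroxymethyl for Methoxy on a Cyclohexyl Ring

The compounds below may be only part of what the source reports. "The series", "measured", "known", "first", "only" and "open" are said of these compounds alone.

Of the compounds shown here, three sharing one core have been measured in an ADME assay on microsomes from liver (Mus musculus) for metabolic stability, read by LC-MS, using NADPH, with a stated time of 10 min, tested at 10 uM; a lower number here means that the compound disappears faster, a higher number that the compound lasts longer. Compound 1, `N#Cc1ccnc(Oc2nn(C3CCC3)c3ncnc(N)c23)c1`, gives 0.4 h. Compound 3, `Nc1ncnc2c1c(Oc1cc(O)ccn1)nn2[C@H]1C[C@H](F)C1`, gives 0.267 h. Compound 2, `Nc1ncnc2c1c(Oc1cc(C(F)(F)F)ccn1)nn2[C@H]1CC[C@@H](CO)CC1`, gives 0.108 h, the lowest of the three numbers; its gap to compound 3 and its larger gap to compound 1 both lie beyond the usual scatter, so among these three compound 2 is the one that disappears fastest.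

Compound 4, `CO[C@H]1CC[C@@H](n2nc(Oc3cc(C(F)(F)F)ccn3)c3c(N)ncnc32)CC1`, has not yet been tested in this assay. It is built from the same atoms as compound 2, joined differently: methoxy in place of hydroxymethyl on a saturated ring carbon. Whether moving the oxygen in this way changes the half-life cannot be read from the measured compounds, since no two of them differ in exactly one place. For the measured compounds named here, with no measured step to lean on, the expected step is a 1.1-fold higher number from compound 2 to compound 4 (0.05 log units; within the scatter), which is to say none beyond the scatter. Compound 4 is therefore expected to give 0.12 h in this assay, with a likely range from 0.06 h to 0.25 h.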

Compound 4, half-life: 0.0333 h
For compound 4 the middle estimate is 3.6-fold (0.56 log units) above the measured one, and the stated range ends above it.
By their numbers in this assay, from the lowest: compound 4; then compound 2; then compounds 3 and 1 (each within the scatter of the next).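

For the compounds shown here, compound 2 and compound 4 are the first pair here that differ in one place only, so the group on this saturated ring carbon can now be judged on its own. In this assay, methoxy in place of hydroxymethyl gives a 3.2-fold lower number from compound 2 to compound 4 (0.51 log units; beyond the scatter) and therefore a compound that disappears faster, which shows that this position responds even when the same atoms are simply joined differently. The change also removes the hydrogen-bond donor of hydroxymethyl, but nothing measured here tells why the half-life shortens.

One pair cannot separate the loss of that donor from the new placement of the oxygen, and it cannot show whether the step would hold on a compound carrying something other than trifluoromethyl on the shared core. An amine, a carboxylic acid or a longer chain such as methoxymethyl on this same ring carbon would show whether the half-life follows the donor, the placement of the oxygen or neither.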